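From fluoromethyl to 1-bromoethyl on a shared core

The source may hold more compounds than are shown below. What is called first, only, known or untested is meant among the compounds shown, and "the series" means these compounds.

In a functional assay on A-431 cells (Homo sapiens) for antiproliferative activity, read by sulforhodamine B assay, with a stated time of 72 h (on this read-out higher numbers stand for weaker inhibition and lower numbers for stronger inhibition), compound 1 (`C=C1CC(CBr)(c2cccc(C)c2)OC1=O`) gives 4500 nM and compound 2 (`C=C1CC(CF)(c2ccccc2)OC1=O`) gives 25100 nM on the same read-out. Compound 2 therefore holds the higher of the two numbers and is the weaker inhibitor of the pair, with a gap to compound 1 that lies beyond the scatter.

Compound 3 (`C=C1CC(c2ccccc2)(C(C)Br)OC1=O`) has not yet been measured. It carries 1-bromoethyl in place of fluoromethyl on a saturated ring carbon. Among the compounds with values here, no pair of measured compounds differs in only one place, so the expectation rests on thin evidence. Within the data shown here, compound 1, at 4500 nM as the only measured compound with a bromine, is the sole guide, and it also differs from compound 3 elsewhere in its structure. In this assay a step toward a lower number, beyond the scatter, is therefore expected, though this remains tentative. The estimated size of that change is given by the expected step (a 3.9-fold lower number from compound 2 to compound 3 (0.59 log units; beyond the scatter)). The estimated value for compound 3 is 6500 nM (expected range 2500 nM to 17000 nM).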

Compound 3, half-maximal inhibitory concentration: 5240 nM
Beside the measured number, compound 3's estimate is 1.2-fold (0.09 log units) above it; the range from low to high includes it.
By their numbers in this assay, from the lowest: compounds 1 and 3 (each within the scatter of the next); then compound 2.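

Within the data shown here, compound 2 and compound 3 give the first readable step at this saturated ring carbon next to the ring oxygen. In this assay, placing 1-bromoethyl where fluoromethyl stood gives a 4.8-fold lower number from compound 2 to compound 3 (0.68 log units; beyond the scatter), so the number on this read-out is sensitive to the group held at this position. The exchange nevertheless alters the halogen and the chain together, so the step belongs to the group as a whole and cannot be divided between bromine and the longer, branched chain, and no separate measurement on these compounds offers an account of it.

The compounds shown leave open whether a chloromethyl or a plain ethyl group on the shared core would read nearer to compound 2 or to compound 3, which would begin to separate the halogen from the chain. Also open, going by these compounds, are how a more different group at this place, such as an aminomethyl group or a carboxylic acid, would read in this assay and whether the same exchange would give a similar step on the core of compound 1.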